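This account rests on a few compounds, and the source may have more. Where it says the series, first, only, none or still open, it means among the compounds named here.

Measured so far:
compound 1 `COc1cc(/C=C\c2ccc3ncccc3c2)cc(OC)c1OC` — 31.6 nM
compound 2 `COc1cc(/C=C\c2ccc3cccnc3c2)cc(OC)c1OC` — 158 nM

In a functional assay on P388 cells (Mus musculus) for cytotoxicity (on this read-out lower numbers stand for stronger inhibition and higher numbers for weaker inhibition), compound 1 gives 31.6 nM, and compound 2 gives 158 nM. Among the measured compounds shown here, compound 2 stands highest of the two numbers; the only other compound, compound 1, sits lower by a gap beyond the scatter.

Compound 3 `COc1cc(/C=C/c2ccc3cccnc3c2)cc(OC)c1OC` is not yet measured. Against compound 2 it shows (the two compounds have the same atoms and bonds and differ only in configuration as drawn: 1 of 1 stereo elements differ; a double bond is drawn Z in compound 2 and E in compound 3). For the measured compounds named here, no measured pair shows such a change, so its size is not known from these data. The expectation for compound 3 is nevertheless a large step toward weaker inhibition, well beyond the scatter, as a 19-fold higher number from compound 2 to compound 3 (1.28 log units; beyond the scatter). Compound 3 is estimated at 3000 nM, within 500 nM to 20000 nM.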

Compound 3, half-maximal inhibitory concentration: 1580 nM
Beside the measured number, compound 3's estimate is 1.9-fold (0.28 log units) above it; measured number inside the range.
By their numbers in this assay, from the lowest: compound 1; then compound 2; then compound 3.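

In this assay, moving the double bond from Z to E gives a 10-fold higher number from compound 2 to compound 3 (1.00 log units; beyond the scatter), the first measured size for this change in the series. Nothing enters or leaves along this step, so the loss of inhibition in this pair goes with configuration alone: the fact that compounds 2 and 3 differ only in the configuration as drawn

On these data alone, whether the Z-to-E step has a similar size on the core of compound 1 stays open. Also open, as far as these compounds go, is how an amine or a hydroxyl group on the shared core would shift the number in the Z or the E form.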